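This account rests on a few compounds, and the source may have more. Where it says the series, first, only, none or still open, it means among the compounds named here.

Three compounds share one core and differ only in the length of a saturated chain that ends in a nitrile and runs from an oxygen on an aromatic ring. Compound 1 `C=CCc1cc(C(C)=O)c(O)cc1OCCCCC#N` gives 57% in an assay on isolated protein for binding affinity to leukotriene B4 receptor 1 (Homo sapiens), tested at 1 uM; on this read-out higher numbers stand for more inhibition at the one concentration tested (going by the name of the read-out) and lower numbers for less inhibition. Compound 2 `C=CCc1cc(C(C)=O)c(O)cc1OCCCCCC#N` gives 41%, and compound 3 `C=CCc1cc(C(C)=O)c(O)cc1OCCCCCCC#N` gives 63%. Compound 3 shows the highest number of the three, but its difference from compound 1 lies within the scatter; only compound 2 sits clearly apart. Lengthening the chain has not moved the numbers in one direction: a number 16 percentage points lower from compound 1 to compound 2 (beyond the scatter), yet a number 22 percentage points higher from compound 2 to compound 3 (beyond the scatter), while a number 6 percentage points higher from compound 1 to compound 3 (within the scatter).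

Compound 4 `C=CCc1cc(C(C)=O)c(O)cc1OCCCCCCCCC#N` extends the chain of compound 3 once more: 2-cyanoethyl in place of cyano on a saturated chain carbon, six bonds along the chain from an oxygen on an aromatic ring. Among the measured compounds shown here, the measured step that most resembles this one is the one from compound 1 to compound 3, the same exchange of cyano for 2-cyanoethyl, which stayed within the scatter. The shorter extensions were larger but pointed in opposite ways, so they offer no direction. The expectation for compound 4 is therefore a step of a number 3 percentage points lower from compound 3 to compound 4 (within the scatter), close to none beyond the scatter, with wide uncertainty. Compound 4 is estimated at 60%, within a range from 40% to 78%.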

Compound 4, a percentage reported as inhibition, at one concentration (the size of the read-out at that concentration, not a potency): 50%
Compound 4: the middle estimate sits 10 percentage points above what was measured; the range from low to high includes it.
By their numbers in this assay, from the lowest: compounds 2, 4, 1 and 3 (each within the scatter of the next, the first and the last beyond it).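

Extending the chain further does not hold the number at the level of compound 3 in this assay: there is a number 13 percentage points lower from compound 3 to compound 4 (beyond the scatter), so the 2-cyanoethyl exchange gives a clear drop at this position, six bonds along the chain from an oxygen on an aromatic ring. The same exchange made four bonds along the chain gave a number 6 percentage points higher from compound 1 to compound 3 (within the scatter), so the outcome of this change depends on where along the chain it is made. The longest chain shown also cannot be told apart from either of the two shortest: there is a number 9 percentage points higher from compound 2 to compound 4 (within the scatter) and also a number 7 percentage points lower from compound 1 to compound 4 (within the scatter), which leaves compound 3 clearly apart only from compound 2 and compound 4, with no steady rise or fall across the four chain lengths.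

No measurement here gives a reason for these ups and downs with chain length. Still open, as far as these compounds go, is whether a longer chain would continue this uneven course, and whether a carboxylic acid or an amine at the chain end in place of the nitrile would give a different number at the same chain length.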